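A few compounds are considered here, and "the series" means these few. Any claim that something is new, unique, unknown or untested is made for them only; others in the source may bear on it.

Compounds measured so far:
compound 1 `Cc1ccnc(N2C(=O)CS[C@@H]2c2cccc(C(=O)NCCCCn3cccn3)c2)c1`: 21.9 nM
compound 2 `Cc1ccnc(N2C(=O)CSC2c2cccc(C(=O)NCCCCn3cccn3)c2)c1`: 19.6 nM

In a functional assay on HOS-TE85 cells (Homo sapiens) for inhibition, read by CCK-8 assay, with a stated time of 72 h (a lower number here means a stronger inhibitor, a higher number a weaker inhibitor), compound 2 gives 19.6 nM, level with compound 1 within the scatter. Compound 3 `O=C(NCCCCn1cccn1)c1cccc(C2SCC(=O)N2c2ccncc2)c1` carries pyridin-4-yl in place of 4-methylpyridin-2-yl on an amide-type nitrogen in a ring. Among the measured compounds shown here, the only measured step, a 1.1-fold lower number from compound 1 to compound 2 (0.05 log units; within the scatter), concerns the fact that one of compounds 1 and 2 is drawn with a defined configuration and the other without, at the place where they differ and leaves this group unchanged, so it gives no guide to the size or direction of the new step. For the measured compounds named here, with no measured precedent, a moderate loss of inhibition is tentatively expected in this assay, as a 5.1-fold higher number from compound 2 to compound 3 (0.71 log units; beyond the scatter). The estimate for compound 3 is 100 nM, with an expected range of 20 nM to 500 nM.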

Compound 3, half-maximal inhibitory concentration: > 1000 nM
Compound 3: only a limit was reported; the forecaster's own chance of this, stated with the estimate: 5%; at least 10-fold (1.00 log units) between middle value and limit.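

In this assay compound 3 gives > 1000 nM as a limit of the assay, not a number. The group on the amide-type nitrogen in a ring, unchanged between compound 1 and compound 2, is not a tolerant position: pyridin-4-yl in place of 4-methylpyridin-2-yl gives an at least 51-fold higher number from compound 2 to compound 3 (1.70 log units; beyond the scatter) with the true size bounded only by that limit. No measured property bears on the cause of this loss.

Open, on these data alone, is whether the loss follows the missing methyl or the change from pyridin-2-yl to pyridin-4-yl, since both change in one step. An unsubstituted pyridin-2-yl group at this position would separate the two.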